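The source may hold more compounds than are shown below. What is called first, only, known or untested is meant among the compounds shown, and "the series" means these compounds.

Measured compounds:
compound 1 `CCS(=O)(=O)CCOc1cc(C)c(-c2cccc(COc3ccc4c(c3)OC[C@H]4CC(=O)O)c2)c(C)c1` — 37 nM
compound 2 `Cc1cc(OC2CCS(=O)(=O)CC2)c(F)c(C)c1-c1cccc(COc2ccc3c(c2)OC[C@H]3CC(=O)O)c1` — 31 nM

In an assay on CHO cells for displacement of a labelled ligand from Free fatty acid receptor 1 (Homo sapiens), read by scintillation counting, with a stated time of 90 min, in the presence of a further agent that is not named here (on this read-out higher numbers stand for weaker inhibition and lower numbers for stronger inhibition), compound 1 gives 37 nM, and compound 2 gives 31 nM. Compound 1 has the higher of the two numbers, yet its gap to compound 2 lies within the scatter of repeated measurements, so the two cannot be told apart. For the measured compounds named here, no pair of measured compounds differing in a single place is available, so there is no reference for how large one change at this position can be.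

Compound 3 `Cc1nc(C)c(COc2cc(C)c(-c3cccc(COc4ccc5c(c4)OC[C@H]5CC(=O)O)c3)c(C)c2)s1` has not yet been measured in this assay. It differs from compound 1 in one place: 2,4-dimethyl-1,3-thiazol-5-yl in place of (ethylsulfonyl)methyl on a saturated chain carbon bound to an oxygen on an aromatic ring. The measured pair gives no hint of how this part of the molecule affects the read-out, so any step in this assay is expected to be small, at most a little beyond the scatter in either direction. Compound 3 is therefore estimated at 45 nM, within 12 nM to 170 nM, which means an expected step of a 1.2-fold higher number from compound 1 to compound 3 (0.09 log units; within the scatter).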

Compound 3, inhibition constant: 12 nM
For compound 3 the middle estimate is 3.8-fold (0.57 log units) above the measured one; measured number inside the range.
By their numbers in this assay, from the lowest: compound 3; then compounds 2 and 1 (each within the scatter of the next).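

In this assay, for the compounds shown here, putting 2,4-dimethyl-1,3-thiazol-5-yl in place of (ethylsulfonyl)methyl on a saturated chain carbon bound to an oxygen on an aromatic ring gives a 3.1-fold lower number from compound 1 to compound 3 (0.49 log units; beyond the scatter), a modest step and the only single-place change available here. It shows that the read-out does respond to what sits at this position, and that the ethylsulfonyl group is not needed for a low number, even though the two groups match in their counted hydrogen-bond donors and acceptors. Nothing measured accounts for the step.

Going by these compounds, the change swaps an open chain for a five-membered aromatic ring carrying two methyl groups in a single move, so it remains open which of these features matters. A 1,3-thiazol-5-yl group without the methyl groups, a phenyl ring or a chain ending in an amine would help to separate them.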